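This account rests on a few compounds, and the source may have more. Where it says the series, first, only, none or still open, it means among the compounds named here.

Working notes on the series. Compound 1 `C=CCSc1nnc(CC)n1N1C(=O)c2ccccc2C1=O` and compound 2 `C=CCSc1nnc(CCC)n1N1C(=O)c2ccccc2C1=O` share a core and are joined by one measured step, a step that the two limits leave unreadable from compound 1 to compound 2. In a functional assay on PC-3M cells (Homo sapiens) for cytotoxicity, read by MTT assay, with a stated time of 48 h (on this read-out lower numbers stand for stronger inhibition and higher numbers for weaker inhibition), compound 1 gives only a limit, > 200000 nM. In this assay compound 2 likewise gives only a limit, > 200000 nM. Both values sit at the limit of > 200000 nM in this assay, at which 2 of the 2 values shown sit, so the step between them cannot be read, and compound 2 stands at the limit with no number behind it. Compound 3 `CCCc1nnc(SCC(=O)c2ccc(C)cc2)n1N1C(=O)c2ccccc2C1=O` carries the next change: (4-methylphenyl)carbonyl in place of vinyl on a saturated chain carbon bound to a sulfur. No measured step bears on this change; the single step shown is unreadable, and nothing in the series gives a size or a direction for what the new group does in this assay. The step from compound 2 to compound 3 is expected at an at least 2.5-fold lower number from compound 2 to compound 3 (0.39 log units; beyond the scatter), with a real chance that only a limit is returned again. Compound 3 is estimated at 80000 nM, within a range from 10000 nM to 250000 nM.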

Compound 3, half-maximal inhibitory concentration: > 200000 nM
Compound 3 ended at the assay's limit; the forecaster's own chance of this, stated with the estimate: 55%; at least 2.5-fold (0.39 log units) between middle value and limit.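

In this assay compound 3 also gives only a limit, > 200000 nM, so the step from compound 2 to compound 3 cannot be read: the limit of > 200000 nM in this assay, at which 3 of the 3 values shown sit.

The compounds shown leave open what size or direction either change has, and what structure on the shared core would return a number in this assay.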